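The source may hold more compounds than are shown below. What is called first, only, known or untested is meant among the compounds shown, and "the series" means these compounds.

Measured so far:
compound 1, `CC(C)c1ccccc1OS(=O)(=O)c1cccc(NC(=O)C(C)(C)C)c1`, 11000 nM
compound 2, `CC(C)c1ccccc1OS(=O)(=O)c1ccc(NC(=O)CCCl)cc1`, 6500 nM
compound 3, `O=C(CCCl)Nc1ccc(S(=O)(=O)Oc2ccccc2I)cc1`, 4200 nM

All three numbers come from a functional assay on HT-1080 cells (Homo sapiens) for antiproliferative activity, read by sulforhodamine B assay, with a stated time of 48 h; a lower number here means a stronger inhibitor, a higher number a weaker inhibitor. Compound 2 stands second highest of the three: its nearest neighbour is compound 3, and the step of a 1.5-fold lower number from compound 2 to compound 3 (0.19 log units; within the scatter) lies within the scatter. Among the measured compounds shown here, compound 1 sits a little higher than compound 2, and these two values also lie within the scatter of each other; no single-point step links them, and the two differ in more than one place. The three measured compounds therefore sit close together in this assay, and none can be called stronger or weaker than another.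

Compound 4, `CC(C)c1ccccc1OS(=O)(=O)c1ccc(NC(=O)NCC2CCCC2)cc1`, is not yet measured. It differs from compound 2 in one place: (cyclopentylmethyl)amino in place of 2-chloroethyl on a carbonyl carbon. For the measured compounds named here, no measured step touches the amide side of the shared core; the one step that exists, from compound 2 to compound 3, concerns the aryl substituent and was within the scatter. There is thus nothing in the numbers that points to a large step in either direction. Compound 4 is expected to give a number close to that of compound 2, with the step of no change at the digits printed from compound 2 to compound 4 (within the scatter) estimated to stay within the scatter. Compound 4 is estimated at 6500 nM, in a range from 1500 nM to 28000 nM.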

Compound 4, half-maximal inhibitory concentration: 6000 nM
Compound 4: the middle estimate sits 1.1-fold (0.03 log units) above what was measured, within the range that was stated.
By their numbers in this assay, from the lowest: compounds 3, 4, 2 and 1 (each within the scatter of the next, the first and the last beyond it).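

Among the compounds shown here, putting (cyclopentylmethyl)amino in place of 2-chloroethyl on a carbonyl carbon gives, in this assay, a 1.1-fold lower number from compound 2 to compound 4 (0.03 log units; within the scatter), the first reading on this side of the shared core; the earlier step, a 1.5-fold lower number from compound 2 to compound 3 (0.19 log units; within the scatter), concerned only the aryl substituent. The change is not a small one in what can be counted: 3 heavy atoms leave, including the chlorine, and 7 enter, bringing a five-membered non-aromatic ring of carbon only and 1 hydrogen-bond donor, yet the two numbers stay within the scatter of each other, so this place tolerates that exchange in this assay without a readable difference. Nothing available offers an explanation for this result.

As far as these compounds go, whether a primary amine, a carboxylic acid or a longer chain on this carbonyl carbon would take the number beyond the scatter remains open, as does whether a phenyl ring here would behave like the cyclopentyl ring. From the compounds shown here alone, it also remains open whether iodo in place of isopropyl would give the same reading alongside the (cyclopentylmethyl)amino group, and steps involving compound 1 cannot be read, since it differs from the others in more than one place.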